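The source may report more compounds than this note shows. Statements on the series, on what has been measured and on what is new or still open speak of the compounds shown alone.

Of the compounds shown here, three built on one shared core have been tested in a functional assay on MKN-74 cells (Homo sapiens) for antiproliferative activity, with a stated time of 24 h; on this read-out lower numbers stand for stronger inhibition and higher numbers for weaker inhibition. Compound 1 `Cc1ccccc1CN1CCc2c(sc(NC(=O)c3ccccc3Cl)c2C(N)=O)C1` gives > 50000 nM in this assay, and this is a limit of the assay rather than a number, so compound 1 stands at the limit of > 50000 nM in this assay, at which 1 of the 3 values shown sits. Compound 2 `NC(=O)c1c(NC(=O)c2ccccc2F)sc2c1CCN(Cc1cccc(Cl)c1)C2` gives 23300 nM in this assay. Compound 3 `NC(=O)c1c(NC(=O)c2cccc([N+](=O)[O-])c2)sc2c1CCN(Cc1ccc(Cl)cc1Cl)C2` gives 16500 nM in this assay. Compound 4 `NC(=O)c1c(NC(=O)c2ccccc2Cl)sc2c1CCN(C(=S)Nc1ccccc1F)C2` has not yet been measured; it differs from compound 1 by a group of 10 heavy atoms (7 carbon, 1 nitrogen, 1 fluorine, 1 sulfur; one six-membered aromatic ring of carbon only) in place of a group of 8 heavy atoms (8 carbon; one six-membered aromatic ring of carbon only), on an amine nitrogen in a ring. Among the measured compounds shown here, no step between measured compounds is known, so the expectation rests on the structural change alone, and the expected step is an at least 1.6-fold lower number from compound 1 to compound 4 (0.22 log units; that floor lies within the scatter), a small move toward stronger inhibition that barely exceeds the scatter. Compound 4 is therefore expected to give 30000 nM, within 8000 nM to 100000 nM.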

Compound 4, half-maximal inhibitory concentration: 12600 nM
Compound 4: middle estimate off by 2.4-fold (0.38 log units), on the high side, within the range that was stated.
By their numbers in this assay, from the lowest: compounds 4, 3 and 2 (each within the scatter of the next). At a limit, above all of these: compound 1.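

Among the compounds shown here, this is the first comparison at the amine nitrogen in a ring. In this assay, replacing the 2-methylbenzyl group with the group that brings sulfur and fluorine gives an at least 3.9-fold lower number from compound 1 to compound 4 (0.59 log units; beyond the scatter), so the group on this nitrogen can move the read-out beyond the scatter. The true size of this step stays unknown because compound 1 sits at a limit: the limit of > 50000 nM in this assay, at which 1 of the 4 values shown sits.

On these data alone, it remains open which part of the entering group matters. A urea carrying oxygen in place of sulfur, or an unsubstituted phenyl ring in place of the fluorinated one, could help separate these parts.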